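From Pyridin-2-yl to 3-Fluorophenyl: Tolerance Expected Unchanged

The compounds below may be only part of what the source reports. "The series", "measured", "known", "first", "only" and "open" are said of these compounds alone.

Compound 1 `CS(=O)(=O)Nc1ccc2c(c1)S(=O)(=O)N=C(C1=C(O)C3CCCC3N(Cc3ccccn3)C1=O)N2` is tested in an ADME assay on Huh-7 cells (Homo sapiens) for cytotoxicity, with a stated time of 72 h; a lower number here means that less compound is tolerated, a higher number that more compound is tolerated. In this assay compound 1 gives > 33000 nM, which is a limit of the assay rather than a number. Compound 2 `CS(=O)(=O)Nc1ccc2c(c1)S(=O)(=O)N=C(C1=C(O)[C@H]3CCC[C@H]3N(Cc3ccc(C(F)(F)F)cc3)C1=O)N2` gives > 33000 nM, also a limit. Compound 3 `CS(=O)(=O)Nc1ccc2c(c1)S(=O)(=O)N=C(C1=C(O)[C@H]3CCC[C@H]3N(Cc3ccc(F)c(Cl)c3)C1=O)N2` gives > 1000 nM, again a limit. The step that the two limits leave unreadable from compound 2 to compound 3 therefore cannot be read, and it concerns a different change anyway. Compound 4 `CS(=O)(=O)Nc1ccc2c(c1)S(=O)(=O)N=C(C1=C(O)C3CCCC3N(Cc3cccc(F)c3)C1=O)N2` differs from compound 1 by 3-fluorophenyl in place of pyridin-2-yl on a saturated chain carbon bound to an amide-type nitrogen in a ring. Among the compounds with values here, no measured step follows this particular change, so no shift beyond the usual scatter is expected, and compound 1 already sits at the limit of > 33000 nM in this assay, at which 2 of the 3 values shown sit. Compound 4 is expected to give 33000 nM, with a range from 10000 nM to 100000 nM. The expected step is a number no higher from compound 1 to compound 4 (the limit leaves the size open).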

Compound 4, half-maximal cytotoxic concentration: > 33000 nM
Compound 4 ended at the assay's limit; the forecaster's own chance of this, stated with the estimate: 85%; the middle value sits exactly at the limit.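

Within the data shown here, compound 1 and compound 4 each stand at a limit of this assay, not at a number, and no step between them can be read. The compounds shown leave open whether 3-fluorophenyl in place of pyridin-2-yl changes tolerance at all.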